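Chloro to methyl on a trimethoxyphenyl-bearing core

The source may hold more compounds than are shown below. What is called first, only, known or untested is meant among the compounds shown, and "the series" means these compounds.

Measured compounds:
compound 1, `CCc1nnc(SCC(=O)c2ccc(Cl)cc2)n1N1C(=O)c2ccccc2C1=O`, > 200000 nM
compound 2, `CCc1nnc(SCC(=O)c2ccc(C)cc2)n1N1C(=O)c2ccccc2C1=O`, > 200000 nM
compound 3, `COc1cc(-c2nnc(SCC(=O)c3ccc(Cl)cc3)n2N2C(=O)c3ccccc3C2=O)cc(OC)c1OC`, 26600 nM

In a functional assay on MKN-45 cells (Homo sapiens) for cytotoxicity, read by MTT assay, with a stated time of 48 h (a lower number here means a stronger inhibitor, a higher number a weaker inhibitor), compound 1 gives > 200000 nM, which is a limit of the assay rather than a number. Compound 2 likewise gives > 200000 nM, again a limit. For the measured compounds named here, compound 3 is the only one with a number, 26600 nM. The change from compound 1 to compound 2 is methyl in place of chloro on an aromatic carbon; its step, a step that the two limits leave unreadable from compound 1 to compound 2, cannot be read because the limit of > 200000 nM in this assay, at which 2 of the 3 values shown sit, holds both values. The two cores differ by 3,4,5-trimethoxyphenyl in place of ethyl on an aromatic carbon, and that step is an at least 7.5-fold lower number from compound 1 to compound 3 (0.87 log units; beyond the scatter).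

Compound 4, `COc1cc(-c2nnc(SCC(=O)c3ccc(C)cc3)n2N2C(=O)c3ccccc3C2=O)cc(OC)c1OC`, has not been measured. It differs from compound 3 by methyl in place of chloro on an aromatic carbon, the same change as that from compound 1 to compound 2, at the same place. The measured pair gives no readable size for that change, so the expectation for compound 4 rests only on compound 3 at 26600 nM and on the small size of the group exchanged. A step of about a 1.3-fold higher number from compound 3 to compound 4 (0.12 log units; within the scatter) is expected. Compound 4 is estimated at 35000 nM, between 12000 nM and 110000 nM.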

Compound 4, half-maximal inhibitory concentration: 9620 nM
Compound 4: the middle estimate sits 3.6-fold (0.56 log units) above what was measured, and the stated range ends above it.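

In this assay, methyl in place of chloro on the trimethoxyphenyl-bearing core gives a 2.8-fold lower number from compound 3 to compound 4 (0.44 log units; beyond the scatter), but the same change on the ethyl-bearing core cannot be read, as compound 1 and compound 2 both sit at a limit of the assay: the limit of > 200000 nM in this assay, at which 2 of the 4 values shown sit. The other change, 3,4,5-trimethoxyphenyl in place of ethyl, gives an at least 20-fold lower number from compound 2 to compound 4 (1.31 log units; beyond the scatter) with methyl on the aromatic ring, and it points the same way with chloro there: the same change on two cores in this assay, an at least 7.5-fold lower number (0.87 log units; beyond the scatter) from compound 1 to compound 3 and an at least 20-fold lower number (1.31 log units; beyond the scatter) from compound 2 to compound 4; the limit leaves it open whether they differ. The series thus shows one change lowering the number on both cores, but it does not show that this change has the same size on both, nor whether the chloro-to-methyl step carries over to the ethyl-bearing core at all.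

The compounds shown leave open how other groups at that place, such as fluoro, methoxy or an amine, would compare with chloro and methyl. They also leave open whether a longer chain or an unsubstituted phenyl in place of ethyl would lower the number as 3,4,5-trimethoxyphenyl does.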